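The source may hold more compounds than are shown below. What is called first, only, known or untested is meant among the compounds shown, and "the series" means these compounds.

Measured so far:
- compound 1, `CCC(Oc1cc(C)nc2ccc(OC)cc12)C(=O)Nc1cc(C)cc(C)c1`: 123000 nM
- compound 2, `COc1ccc2nc(C)cc(OCC(=O)Nc3cc(C)ccc3C)c2c1`: 45500 nM

In a physicochemical assay for solubility, in phosphate buffer, measured as kinetic solubility, with a stated time of 1 h, at pH 7.4 (on this read-out higher numbers stand for higher solubility and lower numbers for lower solubility), compound 2 gives 45500 nM, the lowest of the two numbers measured; compound 1 gives 123000 nM, a gap that lies beyond the scatter of this assay. The two compounds differ in more than one place, so no single change can be read from that gap.

Compound 3, `COc1ccc2nc(C)cc(OCC(=O)Nc3ccc(Cl)cc3Cl)c2c1`, has not yet been measured. It differs from compound 2 in one place: 2,4-dichlorophenyl in place of 2,5-dimethylphenyl on an amide-type nitrogen. Going by the values given here, no step between measured compounds tells how such an exchange moves solubility in this assay, so the expectation rests on compound 2 alone, with wide uncertainty. For compound 3 a step of modest size, downward, is expected, a 1.6-fold lower number from compound 2 to compound 3 (0.21 log units; within the scatter), and the step may well fall within the scatter. The estimate for compound 3 in this assay is 28000 nM, with a range from 9000 nM to 70000 nM.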

Compound 3, solubility: 20500 nM
Estimate against measurement, compound 3: 1.4-fold (0.14 log units) above; low and high end bracket the measured number.
By their numbers in this assay, from the lowest: compound 3; then compound 2; then compound 1.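

In this assay, going by these compounds alone, the exchange of 2,5-dimethylphenyl for 2,4-dichlorophenyl on the amide-type nitrogen gives a 2.2-fold lower number from compound 2 to compound 3 (0.35 log units; beyond the scatter) and is the first change here that can be read on its own. The read-out therefore responds to a change at this place, even though the two groups have the same count of heavy atoms, one aromatic ring of carbon each, no hydrogen-bond donors or acceptors and no net charge. Nothing available explains why the number moves.

The compounds shown leave open whether the chlorine atoms matter together or singly, since no monochlorophenyl group appears among them. They also leave open how a ring carrying an amine or a carboxylic acid at this nitrogen would read.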